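The source may report more compounds than this note shows. Statements on the series, on what has been measured and on what is new or still open speak of the compounds shown alone.

In a functional assay on A549 cells (Homo sapiens) for antiproliferative activity, read by MTT assay (on this read-out lower numbers stand for stronger inhibition and higher numbers for weaker inhibition), the measured compounds are:

- compound 1 `COc1cc2c(Oc3ccc(NC(=O)Nc4ccccc4C(F)(F)F)cc3)ccnc2cc1OCCCCCCC(=O)NO`: 5280 nM
- compound 2 `COc1cc2c(Oc3ccc(NC(=O)Nc4ccc(Cl)c(C(F)(F)F)c4)cc3)ccnc2cc1OCCCCCCC(=O)NO`: 5020 nM

The two values cannot be separated: a 1.1-fold lower number from compound 1 to compound 2 (0.02 log units; within the scatter) lies within the scatter. Compound 2, at 5020 nM, therefore stands level with compound 1 in this assay.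

The unmeasured compound 3 `COc1cc2c(Oc3ccc(NC(=O)NC4CCCCC4)cc3)ccnc2cc1OCCCCCCC(=O)NO` differs from compound 2 in one place: cyclohexyl in place of 4-chloro-3-(trifluoromethyl)phenyl on an amide-type nitrogen. A six-membered aromatic ring of carbon only gives way to a six-membered non-aromatic ring of carbon only, on the same amide-type nitrogen.

Within the data shown here, only one measured step bears on this change, and only partly. That step, a 1.1-fold lower number from compound 1 to compound 2 (0.02 log units; within the scatter), swapped one substituted phenyl for another. Among the measured compounds shown here, no measured compound carries a non-aromatic ring here, so the data do not test this kind of change. With that single small step as the guide, no shift beyond the scatter is expected in this assay, though the range must stay wide. The expected change is a 1.2-fold higher number from compound 2 to compound 3 (0.08 log units; within the scatter). The estimate for compound 3 is 6000 nM, with an expected range from 2500 nM to 14000 nM.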

Compound 3, half-maximal inhibitory concentration: 850 nM
Compound 3: middle estimate off by 7.1-fold (0.85 log units), on the high side; measured number outside the range, below it.
By their numbers in this assay, from the lowest: compound 3; then compounds 2 and 1 (each within the scatter of the next).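

In this assay, the amide-type nitrogen proves sensitive to the kind of ring it carries: cyclohexyl in place of 4-chloro-3-(trifluoromethyl)phenyl gives a 5.9-fold lower number from compound 2 to compound 3 (0.77 log units; beyond the scatter) and cyclohexyl in place of 2-(trifluoromethyl)phenyl gives a 6.2-fold lower number from compound 1 to compound 3 (0.79 log units; beyond the scatter) so that both substituted phenyl compounds are separated from compound 3 by more than the scatter. Among these compounds, the earlier step between the two phenyl groups, a 1.1-fold lower number from compound 1 to compound 2 (0.02 log units; within the scatter) had given no sign of this, since it exchanged only one substituted aromatic ring for another, whereas the cyclohexyl group has a non-aromatic ring of carbon only, carries fewer heavy atoms than 4-chloro-3-(trifluoromethyl)phenyl, and has no chlorine or fluorine. No evidence is available to say why the cyclohexyl compound gives the lower number.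

The compounds shown do not separate the loss of the aromatic ring from the loss of the chlorine and trifluoromethyl substituents, a question that an unsubstituted phenyl group on the same nitrogen would address. They also leave open whether a ring is needed here at all, as an open n-hexyl chain would show, and whether a smaller cyclopentyl or larger cycloheptyl ring would serve as well as cyclohexyl.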